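Permeability across a urea-to-acetamide change on a sulfonylbenzamide series

A few compounds are considered here, and "the series" means these few. Any claim that something is new, unique, unknown or untested is made for them only; others in the source may bear on it.

Measured compounds in a physicochemical assay for permeability, using PAMPA, at pH 7.4; on this read-out lower numbers stand for lower permeability and higher numbers for higher permeability:
- compound 1, `CC(C)NCCS(=O)(=O)NC(=O)c1ccc(Nc2nc(NC3(c4ccc(Cl)cc4)CC3)nc(OCC(F)(F)F)n2)cc1`, gives 45 nm/s
- compound 2, `CC(C)OC(=O)NCCS(=O)(=O)NC(=O)c1ccc(Nc2nc(NC3(c4ccc(Cl)cc4)CC3)nc(OCC(F)(F)F)n2)cc1`, gives 71 nm/s
- compound 3, `CC(C)NC(=O)NCCS(=O)(=O)NC(=O)c1ccc(Nc2nc(NC3(c4ccc(Cl)cc4)CC3)nc(OCC(F)(F)F)n2)cc1`, gives 45 nm/s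

Compound 3 stands level with compound 1 at the digits shown, and the two of them are together the lowest of the three numbers. Its nearest neighbour is compound 1, with no change at the digits printed from compound 1 to compound 3 (within the scatter); its furthest is compound 2, with a 1.6-fold lower number from compound 2 to compound 3 (0.20 log units; within the scatter). The remaining step, a 1.6-fold higher number from compound 1 to compound 2 (0.20 log units; within the scatter), is likewise within the scatter, so none of the three compounds can be ordered against another in this assay.

Compound 4, `CC(=O)NCCS(=O)(=O)NC(=O)c1ccc(Nc2nc(NC3(c4ccc(Cl)cc4)CC3)nc(OCC(F)(F)F)n2)cc1`, has not yet been measured. It differs from compound 3 in one place: methyl in place of isopropylamino on a carbonyl carbon. The bearing steps are those that alter the same terminal group on the sulfonylethyl chain, namely a 1.6-fold higher number from compound 1 to compound 2 (0.20 log units; within the scatter), no change at the digits printed from compound 1 to compound 3 (within the scatter) and a 1.6-fold lower number from compound 2 to compound 3 (0.20 log units; within the scatter). All three stayed within the scatter, so the expectation for compound 4 in this assay is no change beyond the scatter, the estimated step being a 1.1-fold higher number from compound 3 to compound 4 (0.05 log units; within the scatter). Compound 4 is therefore expected to give about 50 nm/s, within a range from 25 nm/s to 100 nm/s.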

Compound 4, apparent permeability: 7 nm/s
Estimate against measurement, compound 4: 7.1-fold (0.85 log units) above; measured number outside the range, below it.
By their numbers in this assay, from the lowest: compound 4; then compounds 1, 3 and 2 (each within the scatter of the next).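

In this assay, for the compounds shown here, the terminal group on the sulfonylethyl chain had so far looked open to change, but compound 4, with its acetamido end, stands apart from all three earlier compounds, with a 6.4-fold lower number from compound 3 to compound 4 (0.81 log units; beyond the scatter) and a 6.4-fold lower number from compound 1 to compound 4 (0.81 log units; beyond the scatter) and also a 10-fold lower number from compound 2 to compound 4 (1.01 log units; beyond the scatter) in the printed steps. Compounds 1, 2 and 3 all carry an isopropyl unit and lie within the scatter of one another, whereas compound 4 lacks that unit and has methyl on the carbonyl carbon, so a carbonyl at this place does not by itself go with the low number, since compounds 2 and 3 also have one. Nothing available here bears on why the number falls with this change.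

The compounds shown leave open whether the low number belongs to methyl itself or would persist with an ethyl group, a longer chain or a cyclopropyl group on the same carbonyl carbon. They also leave open whether a methyl carbamate, a methyl urea or an amide with isopropyl directly on the carbonyl carbon would follow compound 4 or the other three.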